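The source may report more compounds than this note shows. Statements on the series, on what has been measured and on what is new or still open speak of the compounds shown alone.

Measured so far:
- compound 1, `CCC(/C=C(\COC(C)=O)C(=O)c1ccc(OC)cc1)CC`, 9500 nM
- compound 2, `COc1ccc(C(=O)/C(=C/c2ccccc2Cl)COC(=O)c2ccccc2)cc1`, 7000 nM
- compound 3, `CCC(/C=C(\CCOC(C)=O)C(=O)c1ccc(OC)cc1)CC`, 91100 nM

In a functional assay on NB-4 cells (Homo sapiens) for inhibition, read by XTT assay, with a stated time of 48 h (a higher number here means a weaker inhibitor, a lower number a stronger inhibitor), compound 3 gives 91100 nM, the highest number of the three and therefore the weakest inhibitor of this set, since its gaps to compound 1 and compound 2 both lie beyond the scatter. Among the measured compounds shown here, the one step that connects two measured compounds, a 9.6-fold higher number from compound 1 to compound 3 (0.98 log units; beyond the scatter), shows how sensitive this assay is to a small change on the saturated part of the chain.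

Compound 4, `COc1ccc(C(=O)/C(=C/c2ccccc2Cl)CCOC(C)=O)cc1`, has not yet been measured. It differs from compound 3 in one place: 2-chlorophenyl in place of pentan-3-yl on a double-bonded chain carbon bound to a double-bonded chain carbon. For the measured compounds named here, no measured pair shows this exact exchange, so nothing directly tells how large a step it brings. What can be said is that compound 2, which also carries 2-chlorophenyl on that chain carbon, gives 7000 nM, while compound 1, which carries pentan-3-yl, gives 9500 nM; those two values are close to each other, though the pair differs elsewhere too. The expectation is therefore a lower number than compound 3, yet with wide uncertainty, so the step of a 3.0-fold lower number from compound 3 to compound 4 (0.48 log units; beyond the scatter) is estimated as modest. For compound 4 the expected value in this assay is 30000 nM, within a range of 8000 nM to 120000 nM.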

Compound 4, half-maximal inhibitory concentration: 51600 nM
Compound 4: the middle estimate sits 1.7-fold (0.24 log units) below what was measured; low and high end bracket the measured number.
By their numbers in this assay, from the lowest: compounds 2 and 1 (each within the scatter of the next); then compounds 4 and 3 (each within the scatter of the next).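

In this assay, putting 2-chlorophenyl in place of pentan-3-yl on a double-bonded chain carbon bound to a double-bonded chain carbon gives a 1.8-fold lower number from compound 3 to compound 4 (0.25 log units; within the scatter), so with acetoxymethyl held constant, this assay does not separate a ring-free group of five carbons from a chlorine-bearing aromatic ring at this position. The saturated chain carbon tells a different story: with 2-chlorophenyl held constant, acetoxymethyl in place of benzoyloxy gives a 7.4-fold higher number from compound 2 to compound 4 (0.87 log units; beyond the scatter), which joins the earlier 9.6-fold higher number from compound 1 to compound 3 (0.98 log units; beyond the scatter) as a second change at that carbon with a step beyond the scatter, and neither of these two steps goes the other way. Nothing available here gives a reason for any of these steps.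

Going by these compounds, because each step rests on a single pair, it remains open whether pentan-3-yl and 2-chlorophenyl would also stay within the scatter of each other with acetoxy or benzoyloxy on the saturated chain carbon. On these data alone, it is also open how this assay would respond to an amine or a carboxylic acid on either chain carbon, or to a longer chain carrying the ester.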